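A Chain Swapped for a Trifluoromethylphenyl Ring

The compounds below may be only part of what the source reports. "The series", "measured", "known", "first", "only" and "open" are said of these compounds alone.

Compound 1 `CCCCCCCCNc1nc(SCc2ccc(C(F)(F)F)cc2)nc2ccccc12` gives 22300 nM in a functional assay on MDA-MB-231 cells (Homo sapiens) for cytotoxicity, read by MTT assay, with a stated time of 72 h; a lower number here means a stronger inhibitor, a higher number a weaker inhibitor. Among the three measured compounds it stands second highest. Compound 2 `FC(F)(F)c1ccc(CSc2nc(N3CCCCC3)c3ccccc3n2)cc1` gives 28400 nM, and the step of a 1.3-fold higher number from compound 1 to compound 2 (0.11 log units; within the scatter) lies within the scatter. Compound 3 `Fc1ccc(Nc2nc(SCc3ccc(C(F)(F)F)cc3)nc3ccccc23)cc1` gives 15000 nM, and the step of a 1.5-fold lower number from compound 1 to compound 3 (0.17 log units; within the scatter) is also within the scatter.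

Compound 4 `FC(F)(F)c1ccc(CSc2nc(Nc3ccc(C(F)(F)F)cc3)c3ccccc3n2)cc1` differs from compound 1 in one place: 4-(trifluoromethyl)phenyl in place of octyl on a nitrogen on an aromatic ring. Going by the values given here, the step that most resembles this is the one from compound 1 to compound 3, where an aromatic ring likewise replaced the octyl chain, and that step a 1.5-fold lower number from compound 1 to compound 3 (0.17 log units; within the scatter) stayed within the scatter. The expected step in this assay is therefore a 1.4-fold lower number from compound 1 to compound 4 (0.14 log units; within the scatter), small and without a clear direction. Compound 4 is expected at 16000 nM, within 6000 nM to 40000 nM.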

Compound 4, half-maximal inhibitory concentration: 5460 nM
The estimate for compound 4 lay 2.9-fold (0.47 log units) above the measured number, and the stated range ends above it.
By their numbers in this assay, from the lowest: compound 4; then compounds 3, 1 and 2 (each within the scatter of the next).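

At this nitrogen, the earlier swaps stayed within the scatter in this assay, but 4-(trifluoromethyl)phenyl moves the number beyond it, both in place of octyl (a 4.1-fold lower number from compound 1 to compound 4 (0.61 log units; beyond the scatter)) and in place of piperidin-1-yl (a 5.2-fold lower number from compound 2 to compound 4 (0.72 log units; beyond the scatter)). An aromatic ring alone does not give the whole change, since trifluoromethyl in place of fluoro on that ring also counts (a 2.7-fold lower number from compound 3 to compound 4 (0.44 log units; beyond the scatter)). Nothing available explains these steps. Still open, going by these compounds, is whether a nitrile or a methoxy group in place of trifluoromethyl would give a similar number.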